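The source may report more compounds than this note shows. Statements on the series, on what has been measured and on what is new or still open speak of the compounds shown alone.

Compound 1, `CC1=CC[C@H](C(C)(C)NC(=S)N/N=C/c2ccccc2)CC1`, gives 67000 nM in a functional assay on 786-0 cells (Homo sapiens) for inhibition, read by sulforhodamine B assay, with a stated time of 48 h; on this read-out higher numbers stand for weaker inhibition of growth and lower numbers for stronger inhibition of growth.
Compound 2, `CC1=CC[C@H](C(C)(C)NC(=S)N/N=C/c2ccc(O)cc2)CC1`, reaches only a limit in this assay, recorded as > 100000 nM.

Among these, compound 1 holds the only number read as a value; the value for compound 2 is a limit of the measurement and not a number, as the limit of > 100000 nM in this assay, at which 1 of the 2 values shown sits, makes clear. Among the compounds with values here, the single measured step, an at least 1.4-fold higher number from compound 1 to compound 2 (0.17 log units; that floor lies within the scatter), comes from a hydroxy in place of hydrogen on an aromatic carbon and is itself only a floor, so it tells little about direction.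

Compound 3, `CC1=CC[C@H](C(C)(C)NC(=S)N/N=C/c2ccc[nH]2)CC1`, is related to compound 1 by 1H-pyrrol-2-yl in place of phenyl on a carbon with a double bond to nitrogen. Within the data shown here, no measured step replaces phenyl with a five-membered ring, so the change from compound 1 to compound 3 has no direct precedent here, and the one step that is known, from compound 1 to compound 2, sets no firm size. Compound 3 is therefore expected to stay close to compound 1 in this assay, with a step of a 1.0-fold higher number from compound 1 to compound 3 (0.02 log units; within the scatter) that lies within the scatter. The estimate for compound 3 is 70000 nM, in a range from 25000 nM to 200000 nM.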

Compound 3, concentration for total growth inhibition: > 100000 nM
Compound 3: only a limit was reported (the forecaster's own chance of this, stated with the estimate: 35%); at least 1.4-fold (0.15 log units) between middle value and limit.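

Replacing phenyl with 1H-pyrrol-2-yl on a carbon with a double bond to nitrogen gives an at least 1.4-fold higher number from compound 1 to compound 3 (0.17 log units; that floor lies within the scatter), so this step, like the earlier hydroxy step, is only a floor and fixes no size. The earlier compounds shown here showed a limit only for a change on the phenyl ring, whereas compound 3 shows that exchanging the whole ring at this place can also end at a limit in this assay, where the > 100000 nM of compound 3 is a limit and not a number. Compound 1 remains the only compound of the three with a number read as a value, and the measurements now gather at the limit: the limit of > 100000 nM in this assay, at which 2 of the 3 values shown sit.

The step from compound 2 to compound 3 cannot be read, both values being limits. Left open is how far either change moves the true value, and whether another group on this carbon, such as a phenyl carrying an amine or a carboxylic acid, would give a number lower than that of compound 1.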